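Pyridin-3-yl in place of methyl on the ring nitrogen

The source may report more compounds than this note shows. Statements on the series, on what has been measured and on what is new or still open speak of the compounds shown alone.

Compound 1 `O=C1/C(=C/N2N=C(c3ccccc3)CC2c2ccccc2O)SC(=S)N1c1cccnc1` gives > 10000 nM in a functional assay on SK-OV-3 cells (Homo sapiens) for antiproliferative activity, read by MTT assay, with a stated time of 72 h (on this read-out lower numbers stand for stronger inhibition and higher numbers for weaker inhibition), a limit of the assay rather than a number.
Compound 2 `CC(=O)Oc1ccc(N2C(=O)/C(=C/N3N=C(c4ccc5ccccc5c4)CC3c3ccccc3O)SC2=S)cc1` gives > 10000 nM in this assay, again a limit.
Compound 3 `CN1C(=O)/C(=C/N2N=C(c3ccc4ccccc4c3)CC2c2ccccc2O)SC1=S` gives > 10000 nM in this assay, also a limit.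

Compound 3 thus stands at the assay limit, with no number of its own. All three measured values sit at that same limit (the limit of > 10000 nM in this assay, at which 3 of the 3 values shown sit). For the measured compounds named here, the only measured step, a step that the two limits leave unreadable from compound 2 to compound 3, runs between two limits and its size cannot be read. Compound 4 `O=C1/C(=C/N2N=C(c3ccc4ccccc4c3)CC2c2ccccc2O)SC(=S)N1c1cccnc1` differs from compound 3 by pyridin-3-yl in place of methyl on an amide-type nitrogen in a ring. Going by the values given here, no measured step speaks directly to this change. Compound 1 already carries pyridin-3-yl on the same nitrogen and sits at the limit as well. Compound 4 is therefore expected to remain at or near the limit, a step that the limit leaves unreadable from compound 3 to compound 4 that cannot be read as beyond the scatter. The estimate for compound 4 is 15000 nM, ranging from 5000 nM to 50000 nM.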

Compound 4, half-maximal inhibitory concentration: 5590 nM
Estimate against measurement, compound 4: 2.7-fold (0.43 log units) above; low and high end bracket the measured number.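

Compound 4 is the only compound shown to give a number rather than a limit in this assay: the limit of > 10000 nM in this assay, at which 3 of the 4 values shown sit. Pyridin-3-yl in place of methyl gives an at least 1.7-fold lower number from compound 3 to compound 4 (0.25 log units; that floor lies within the scatter), pyridin-3-yl in place of 4-acetoxyphenyl gives an at least 1.7-fold lower number from compound 2 to compound 4 (0.25 log units; that floor lies within the scatter), and naphthalen-2-yl in place of phenyl gives an at least 1.7-fold lower number from compound 1 to compound 4 (0.25 log units; that floor lies within the scatter). As far as these compounds go, each of these is only a floor, so the true size of the steps remains unknown and none can be called beyond the scatter.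

From the compounds shown here alone, it remains open how a plain phenyl or a pyridin-4-yl on the same nitrogen would read, or an amine on the naphthalen-2-yl.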